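The source may report more compounds than this note shows. Statements on the series, on what has been measured and on what is new or still open speak of the compounds shown alone.

Working notes on the series. In an ADME assay on MDCKII-LE cells (Canis lupus familiaris) for permeability, with a stated time of 1.5 h (a lower number here means that the compound crosses the layer more slowly, a higher number that the compound crosses the layer faster), compound 1 `Cc1cccnc1N(C(=O)N1CCC(c2ccccc2)CC1)[C@@H]1CCCNC1` gives 8.7 10^-6 cm/s. Compound 3 `COc1ccc(CCC(=O)N(c2nccc3ccccc23)[C@@H]2CCCNC2)cc1` gives 5.4 10^-6 cm/s in this assay, which lies within the scatter of the value of compound 1. Compound 2 `O=C(N1CCC(c2cnn3cccnc23)CC1)N(c1ncccc1Cl)[C@@H]1CCCNC1` gives 1.8 10^-6 cm/s, a gap to compound 1 that is beyond the scatter. Going by the values given here, no step between two compounds that differ in one place has been measured in this assay.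

Compound 4 `O=C(N1CCC(c2ccccc2)CC1)N(c1nccc2ccccc12)[C@@H]1CCCNC1` has not been measured. It differs from compound 1 as follows: isoquinolin-1-yl in place of 3-methylpyridin-2-yl on an amide-type nitrogen. Among the compounds with values here, the only other compound carrying isoquinolin-1-yl is compound 3, whose value 5.4 10^-6 cm/s sits within the scatter of compound 1, so the expected step of a 1.2-fold lower number from compound 1 to compound 4 (0.09 log units; within the scatter) is small, at most a slight decrease. The estimate for compound 4 in this assay is 7 10^-6 cm/s, with a range of 3.5 10^-6 cm/s to 14 10^-6 cm/s.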

Compound 4, apparent permeability: 3.9 10^-6 cm/s
Beside the measured number, compound 4's estimate is 1.8-fold (0.25 log units) above it; the measured number falls inside the stated range.
By their numbers in this assay, from the lowest: compound 2; then compounds 4, 3 and 1 (each within the scatter of the next, the first and the last beyond it).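

Going by these compounds alone, this is the first step read at a single place: in this assay, isoquinolin-1-yl in place of 3-methylpyridin-2-yl on the amide-type nitrogen gives a 2.2-fold lower number from compound 1 to compound 4 (0.35 log units; beyond the scatter) with the rest of the structure unchanged. The step is modest, but it shows that this position is not silent to a change of aromatic group. Nothing at hand bears on the reason for the step.

Still open, as far as these compounds go, is whether the step follows the added aromatic ring or the lost methyl. An unsubstituted pyridin-2-yl on the same nitrogen would separate the two.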